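Removing the protecting group from compound 3

A few compounds are considered here, and "the series" means these few. Any claim that something is new, unique, unknown or untested is made for them only; others in the source may bear on it.

Measured in a functional assay on MCF7 cells (Homo sapiens) for inhibition, read by MTT assay, with a stated time of 72 h; on this read-out lower numbers stand for stronger inhibition and higher numbers for weaker inhibition:
Compound 1 `CC(C)[C@H](NC(=O)c1cc(Cl)ccc1OCCCNC(=O)OC(C)(C)C)C(=O)Nc1ccc([N+](=O)[O-])cc1Cl`: > 10000 nM, a limit
Compound 2 `CC(C)[C@H](NC(=O)c1cc(Cl)ccc1OCCNC(=O)OC(C)(C)C)C(=O)Nc1ccc(C(F)(F)F)cc1Cl`: > 10000 nM, a limit
Compound 3 `CC(C)[C@H](NC(=O)c1cc(Cl)ccc1OCCNC(=O)OC(C)(C)C)C(=O)Nc1cc(F)cc(C(F)(F)F)c1`: 11500 nM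

Among the compounds with values here, compound 3 holds the only true number in this small set, since the other two entries are limits and not measurements. All three compounds carry tert-butoxycarbonyl.

Compound 4 `CC(C)[C@H](NC(=O)c1cc(Cl)ccc1OCCN)C(=O)Nc1cc(F)cc(C(F)(F)F)c1` has hydrogen in place of tert-butoxycarbonyl on an amine nitrogen, and the change is counted here: hydrogen in place of tert-butoxycarbonyl on an amine nitrogen. Within the data shown here, no measured step tests this change. Among the measured compounds shown here, the one step available, a step that the limit leaves unreadable from compound 2 to compound 3, has no readable size and concerns a different group, so it gives no size to carry over.

The expectation therefore starts from compound 3 and stays wide. With compound 3 at 11500 nM, the expectation for compound 4 leans toward stronger inhibition in this assay. The expected change is modest: a 2.3-fold lower number from compound 3 to compound 4 (0.36 log units; beyond the scatter). For compound 4 the estimated value is 5000 nM, with an expected range of 1500 nM to 15000 nM.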

Compound 4, half-maximal inhibitory concentration: > 10000 nM
Compound 4 ended at the assay's limit; the forecaster's own chance of this, stated with the estimate: 20%; middle value at least 2.0-fold (0.30 log units) from the limit.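

No size can be read for the step from compound 3 to compound 4, since the result for compound 4 is a limit and not a number: the limit of > 10000 nM in this assay, at which 3 of the 4 values shown sit. The compounds shown leave open how strongly compound 4 inhibits in this assay, and whether hydrogen in place of tert-butoxycarbonyl on an amine nitrogen strengthens or weakens inhibition.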